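Three Stereoisomers Measured, a Fourth Estimated

The source may hold more compounds than are shown below. What is called first, only, known or untested is meant among the compounds shown, and "the series" means these compounds.

Four stereoisomers of one dipeptide-like acid are considered here. Compound 1 `O=C(N[C@H](CO)C(=O)O)[C@@H]1C[C@@H](O)CN1`, compound 2 `O=C(O)[C@H](CO)NC(=O)[C@H]1C[C@H](O)CN1` and compound 3 `O=C(O)[C@H](CO)NC(=O)[C@@H]1C[C@@H](O)CN1` have been measured in an ADME assay (Mus musculus, strain C57BL/6) for metabolic stability, read by HPLC, with a stated time of 12 h; a lower number here means that the compound disappears faster, a higher number that the compound lasts longer; compound 4 `O=C(O)[C@@H](CO)NC(=O)[C@H]1C[C@@H](O)CN1` has not.

In this assay compound 1 gives 0.99 h. Compound 2 reaches only the limit of the assay, > 12 h, and no number. Compound 3 gives 0.88 h, and compound 1 stands nearest to it, with a 1.1-fold lower number from compound 1 to compound 3 (0.05 log units; within the scatter).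

Compound 4 differs from compound 3 as follows: the two compounds have the same atoms and bonds and differ only in configuration as drawn: 2 of 3 stereo elements differ; a stereocentre at a saturated chain carbon is drawn S in compound 3 and R in compound 4; a stereocentre at a saturated ring carbon is drawn S in compound 3 and R in compound 4. Compound 4 thus shares the chain stereocentre with compound 1, while one ring stereocentre is drawn as in compound 2 and the other as in compound 3. Within the data shown here, the steps that bear on this are an at least 13-fold lower number from compound 2 to compound 3 (1.13 log units; beyond the scatter) and an at least 12-fold higher number from compound 1 to compound 2 (1.08 log units; beyond the scatter), both large and both involving the two ring stereocentres at once, whereas inverting the chain stereocentre alone gave a step within the scatter. Among the measured compounds shown here, no measured step separates the two ring stereocentres from each other, so the size of the step to compound 4 is uncertain; a rise beyond the scatter is expected, though possibly smaller than the full step between compound 3 and compound 2. Compound 4 is therefore estimated at 3 h, with a range from 0.9 h to 12 h. That estimate means an expected step of a 3.4-fold higher number from compound 3 to compound 4 (0.53 log units; beyond the scatter).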

Compound 4, half-life: > 12 h
Compound 4 was reported as a limit; the forecaster's own chance of this, stated with the estimate: 25%; middle value at least 4.0-fold (0.60 log units) from the limit.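

Among these compounds, the result gives an at least 12-fold higher number from compound 1 to compound 4 (1.08 log units; beyond the scatter), the first step here that rests on a single ring stereocentre, drawn S in compound 1 and R in compound 4, and it can be tied to that stereocentre because nothing else changes: the fact that compounds 1 and 4 differ only in the configuration as drawn. Inverting the chain stereocentre together with this ring stereocentre gives an at least 13-fold higher number from compound 3 to compound 4 (1.13 log units; beyond the scatter), whereas the chain stereocentre alone gave a 1.1-fold lower number from compound 1 to compound 3 (0.05 log units; within the scatter), so the large steps seen earlier no longer need both ring stereocentres to change at once. Compound 4 gives > 12 h in this assay, which is a limit and not a number.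

Compound 2 and compound 4 both sit at the limit and the step between them cannot be read, which leaves open whether the other ring stereocentre adds anything to the half-life. Also open, on these data alone, is how this ring stereocentre would act with an amine in place of the ring hydroxyl, or with a methyl ester in place of the carboxylic acid.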